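This account rests on a few compounds, and the source may have more. Where it says the series, first, only, none or still open, it means among the compounds named here.

Of the compounds shown here, three built on one shared core have been tested in a functional assay on blood (Homo sapiens), with a stated time of 60 min, in the presence of a further agent that is not named here; a higher number here means that more compound is needed for the effect, a lower number that less compound is needed. Compound 1 (`CON(C)C(=O)C1(S(=O)(=O)c2ccc(Oc3ccc(OC(F)(F)F)cc3)cc2)CCC2(CCNCC2)C1`) gives 3700 nM. Compound 2 (`COC(=O)C1(S(=O)(=O)c2ccc(Oc3ccc(OC(F)(F)F)cc3)cc2)CCC2(CCNCC2)C1`) gives only a limit of the assay, > 15000 nM. From the compounds shown here alone, compound 3 (`O=C(Nc1ccccn1)C1(S(=O)(=O)c2ccc(Oc3ccc(OC(F)(F)F)cc3)cc2)CCC2(CCNCC2)C1`) likewise gives only a limit, > 15000 nM, so its true position is unknown.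

Compound 4 (`CS(=O)(=O)NC(=O)C1(S(=O)(=O)c2ccc(Oc3ccc(OC(F)(F)F)cc3)cc2)CCC2(CCNCC2)C1`) has methylsulfonyl in place of pyridin-2-yl on an amide-type nitrogen. The measured steps that bear on this change all alter the group on the same carbonyl carbon. The data show an at least 4.0-fold higher number from compound 1 to compound 2 (0.60 log units; beyond the scatter) and an at least 4.0-fold higher number from compound 1 to compound 3 (0.60 log units; beyond the scatter), while the comparison gives a step that the two limits leave unreadable from compound 2 to compound 3. Only compound 1 gives a number, and compound 2 and compound 3 both sit at the limit of > 15000 nM in this assay, at which 2 of the 3 values shown sit.

Neither measured step tests the new group directly, so no clear step is expected in this assay, and a result at the limit is quite possible. The expected step is an at least 1.0-fold lower number from compound 3 to compound 4 (0.02 log units; that floor lies within the scatter). The estimate for compound 4 is 14000 nM, with an expected range of 4000 nM to 45000 nM.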

Compound 4, half-maximal effective concentration: > 15000 nM
Compound 4: only a limit was reported; the forecaster's own chance of this, stated with the estimate: 55%; middle value at least 1.0-fold (0.02 log units) away from the limit.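

In this assay compound 4 gives > 15000 nM, which is a limit of the assay and not a number. Placing methylsulfonyl instead of pyridin-2-yl on the amide-type nitrogen therefore does not bring the compound off the limit, and methanesulfonamido now joins the other replacements for methoxy(methyl)amino on this carbonyl carbon in giving a higher number, with an at least 4.0-fold higher number from compound 1 to compound 4 (0.60 log units; beyond the scatter). The steps among compound 2, compound 3 and compound 4 cannot be read, and only compound 1 gives a number, so most of this small set gathers at one end of the scale: the limit of > 15000 nM in this assay, at which 3 of the 4 values shown sit.

From the compounds shown here alone, how far apart compound 2, compound 3 and compound 4 truly lie remains open. Also open, going by these compounds, is whether a dimethylamino group or a carboxylic acid on the same carbonyl carbon would give a number rather than a limit.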